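Amine Variation on the Fused Core: Dose Expectation

A few compounds are considered here, and "the series" means these few. Any claim that something is new, unique, unknown or untested is made for them only; others in the source may bear on it.

Two compounds of the series carry a result in a functional assay on the whole organism with Rattus norvegicus as the target; on this read-out lower numbers stand for an effect already at smaller amounts and higher numbers for an effect only at larger amounts of compound. Compound 1, `Cc1nc2c(OCc3cccs3)cccn2c1N`, gives 5 mg/kg. Compound 2, `Cc1nc2c(OCc3ccccc3)cccn2c1NC=O`, gives 10 mg/kg. Of the two numbers shown, compound 2 holds the higher one, but its only neighbour, compound 1, sits within the usual scatter of such measurements, so the pair does not separate. For the measured compounds named here, no step between measured compounds that differ in a single place exists in the set.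

Compound 3, `CCCN(CCC)c1c(C)nc2c(OCc3ccccc3)cccn12`, is still to be measured. It differs from compound 2 in one place: dipropylamino in place of formylamino on an aromatic carbon. Going by the values given here, no measured pair shows what this exchange does, so any expectation rests on the structural change alone. The expected step, a 2.0-fold higher number from compound 2 to compound 3 (0.30 log units; within the scatter), is an increase in dose, moderate in size and probably beyond the scatter. For compound 3 the estimate in this assay is 20 mg/kg, with a range from 6 mg/kg to 70 mg/kg.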

Compound 3, dose for half-maximal effect: 8.4 mg/kg
For compound 3 the middle estimate is 2.4-fold (0.38 log units) above the measured one, and the stated range covers the measured number.
By their numbers in this assay, from the lowest: compounds 1, 3 and 2 (each within the scatter of the next).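

In this assay, dipropylamino in place of formylamino on an aromatic carbon of the five-membered aromatic ring gives a 1.2-fold lower number from compound 2 to compound 3 (0.08 log units; within the scatter). For the compounds shown here, this is the first single-place step at this position, which the earlier compounds could not provide. The entering group has more heavy atoms and no hydrogen-bond donor, yet compound 2 and compound 3 do not separate on this read-out. Nothing measured here bears on why the two compounds do not separate.

Going by these compounds, it remains open whether dimethylamino, a piperidine ring or acetylamino at the same carbon would also stay within the scatter of these two compounds. With a single step at this position, no trend across amino groups can be stated, and the pair alone does not show how far the position tolerates exchange.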